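Two stereocentres inverted in a cyclic integrin ligand

A few compounds are considered here, and "the series" means these few. Any claim that something is new, unique, unknown or untested is made for them only; others in the source may bear on it.

Compound 2 `N=C(N)NCCC[C@@H]1NC(=O)CC(=O)N[C@@H](CC(=O)O)C(=O)N[C@H](Cc2ccccc2)CNC1=O` is the stronger of the two measured ring compounds: in an assay on K562 cells for inhibition of integrin alpha-5/beta-1 (Homo sapiens), with a stated time of 30 min (a lower number here means a stronger inhibitor, a higher number a weaker inhibitor), compound 2 gives 24 nM, while compound 1 `N=C(N)NCCC[C@@H]1NC(=O)CC(=O)N[C@@H](CC(=O)O)C(=O)N[C@@H](Cc2ccccc2)CNC1=O` gives 520 nM. The only difference between them is a stereocentre at a saturated ring carbon, drawn S in compound 1 and R in compound 2, and that single inversion produced a 22-fold lower number from compound 1 to compound 2 (1.34 log units; beyond the scatter). Compound 3 `N=C(N)NCCC[C@H]1NC(=O)CC(=O)N[C@@H](CC(=O)O)C(=O)N[C@@H](Cc2ccccc2)CNC1=O` differs from compound 2 in two places: the two compounds have the same atoms and bonds; at least one stereo element is drawn with a configuration in one of them and without one in the other: 2 of 4 stereo elements differ; a stereocentre at a saturated ring carbon is drawn S in compound 2 and R in compound 3; a stereocentre at a saturated ring carbon is drawn R in compound 2 and S in compound 3. One of these inversions returns the phenyl-bearing carbon to the configuration of compound 1, which on its own undid the whole gain seen from compound 1 to compound 2. Going by the values given here, the second inversion, at the carbon carrying the guanidine chain, has no measured counterpart here. Compound 3 is therefore expected to be weaker than compound 2, with a step of a 17-fold higher number from compound 2 to compound 3 (1.22 log units; beyond the scatter), and its estimated value is 400 nM, within 60 nM to 3000 nM.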

Compound 3, half-maximal inhibitory concentration: 4700 nM
The estimate for compound 3 lay 12-fold (1.07 log units) below the measured number; the whole stated range lies below it.
By their numbers in this assay, from the lowest: compound 2; then compound 1; then compound 3.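

Inverting only the carbon carrying the guanidine chain gives, in this assay, a 9.0-fold higher number from compound 1 to compound 3 (0.96 log units; beyond the scatter). This centre therefore counts in its own right, and the phenyl-bearing carbon is not the only stereocentre to which the number responds. With both centres changed, the result is a 200-fold higher number from compound 2 to compound 3 (2.29 log units; beyond the scatter), the largest step among these compounds, but this step adds no separate information: it is simply the route from compound 2 back to compound 1 followed by the single inversion to compound 3.

From the compounds shown here alone, whether inverting the guanidine-bearing carbon costs as much when the phenyl-bearing carbon keeps the configuration of compound 2 remains open, and answering it would take the stereoisomer with that combination. The compounds shown also leave open what a primary amine in place of the guanidine, or a shorter chain carrying it, would do.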